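The source may report more compounds than this note shows. Statements on the series, on what has been measured and on what is new or still open speak of the compounds shown alone.

Measured so far:
compound 1 `Nc1c(C(=O)N/N=C/c2ccc(Br)cc2)oc2nc(-c3cccs3)cc(C(F)(F)F)c12` — 6100 nM
compound 2 `Nc1c(C(=O)NC2CCCC2)oc2nc(-c3ccccc3)cc(C(F)(F)F)c12` — 32400 nM
compound 3 `CNC(=O)c1oc2nc(-c3ccccc3)cc(C(F)(F)F)c2c1N` — 41200 nM

In a functional assay on HepG2 cells (Homo sapiens) for antiproliferative activity, read by MTT assay (on this read-out higher numbers stand for weaker inhibition and lower numbers for stronger inhibition), compound 1 gives 6100 nM, the lowest of the three numbers. Compound 2 gives 32400 nM and compound 3 gives 41200 nM, and both gaps from compound 1 lie beyond the scatter. Compound 1 differs from compound 2 and compound 3 in several places at once, so its lower number cannot be tied to any one group.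

Among the measured compounds shown here, the single one-place step in hand is a 1.3-fold higher number from compound 2 to compound 3 (0.10 log units; within the scatter), a change on the amide-type nitrogen that does not bear on the aryl ring of the hydrazone.

Compound 4 `Nc1c(C(=O)N/N=C/c2ccccc2)oc2nc(-c3cccs3)cc(C(F)(F)F)c12` differs from compound 1 by hydrogen in place of bromo on an aromatic carbon. For the measured compounds named here, no measured pair shows this change, and the one step known concerns a different part of the shared core. With nothing to anchor the change, the working expectation is a small step in this assay, if anything toward a higher number, and quite possibly within the scatter. Compound 4 is estimated at 9000 nM, within 4000 nM to 25000 nM, which corresponds to an expected step of a 1.5-fold higher number from compound 1 to compound 4 (0.17 log units; within the scatter).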

Compound 4, half-maximal inhibitory concentration: 9900 nM
Compound 4: middle estimate off by 1.1-fold (0.04 log units), on the low side; the measured number falls inside the stated range.
By their numbers in this assay, from the lowest: compounds 1 and 4 (each within the scatter of the next); then compounds 2 and 3 (each within the scatter of the next).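

In this assay this position now has its first direct reading, a 1.6-fold higher number from compound 1 to compound 4 (0.21 log units; within the scatter), for the change from 4-bromophenyl to phenyl. For this pair, the step does not separate from the scatter, so the bromo is not needed for compound 4 to give 9900 nM in this assay, and no role for the bromo can be read from these two compounds. This holds only on the core of compound 1 and for this single substitution, and nothing measured here accounts for the closeness of the pair.

Still open, going by these compounds, is whether any other group at this place on the six-membered aromatic ring, such as a methoxy, an amine or a carboxylic acid, would give a step beyond the scatter, and whether hydrogen in place of bromo would read the same on a different core. Among the compounds shown here, also open is which part of compound 1 and compound 4 goes with their numbers, since no one-place step yet links either of them to compound 2 or compound 3.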